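Quinoxaline-fused spirooxindole triazoles: antiproliferative screen on HUVEC cells

This account rests on a few compounds, and the source may have more. Where it says the series, first, only, none or still open, it means among the compounds named here.

Measured so far:
compound 1, `N#CC1=C(N)Oc2c(c3nc4ccccc4nc3c3ccccc23)C12C(=O)N(Cc1cnnn1-c1ccc(Cl)c(Cl)c1)c1ccccc12`, > 50000 nM
compound 2, `CCOc1ccccc1-n1nncc1CN1C(=O)C2(C(C#N)=C(N)Oc3c(N)cc4nc5ccccc5nc4c32)c2ccccc21`, > 50000 nM

In an ADME assay on HUVEC cells (Homo sapiens) for antiproliferative activity, read by MTT assay, with a stated time of 48 h (on this read-out lower numbers stand for stronger inhibition and higher numbers for weaker inhibition), compound 1 gives > 50000 nM, a limit of the assay rather than a number. In this assay compound 2 likewise gives > 50000 nM, again a limit. Going by the values given here, both values shown therefore sit at the same limit, (the limit of > 50000 nM in this assay, at which 2 of the 2 values shown sit), and nothing can be said of any order between compound 1 and compound 2; they also differ in more than one place, so no single step is counted between them.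

Compound 3, `N#CC1=C(N)Oc2c(N)cc3nc4ccccc4nc3c2C12C(=O)N(Cc1cnnn1-c1c(Cl)cc(Cl)cc1Cl)c1ccccc12`, has not been measured in this assay. Against compound 2 the change is 2,4,6-trichlorophenyl in place of 2-ethoxyphenyl on an aromatic nitrogen.

Among the compounds with values here, with no measured step and both measured values at the limit, no direction can be read for this change; the only basis is that compound 2 gives > 50000 nM, a limit. The step from compound 2 to compound 3 is expected to be a step that the limit leaves unreadable from compound 2 to compound 3, which is none beyond the scatter. Compound 3 is accordingly estimated at 70000 nM, between 20000 nM and 250000 nM, with the result most likely to be reported as a limit again.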

Compound 3, half-maximal inhibitory concentration: 18300 nM
The estimate for compound 3 lay 3.8-fold (0.58 log units) above the measured number; the whole stated range lies above it.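

Going by these compounds alone, the aromatic nitrogen of the five-membered aromatic ring with 3 nitrogen is the first place to give a readable change in this assay: 2,4,6-trichlorophenyl in place of 2-ethoxyphenyl gives an at least 2.7-fold lower number from compound 2 to compound 3 (0.43 log units; beyond the scatter). With compound 3 at 18300 nM, a measured number rather than a limit, the group on this nitrogen can move the read-out on the core shared by compound 2 and compound 3, which the earlier values could not show. The true size of the step remains unknown, and only its lower bound can be stated, because the starting value is a limit: the limit of > 50000 nM in this assay, at which 2 of the 3 values shown sit.

The single exchange removes the ethoxy group and adds three chlorine atoms at once, so the compounds shown do not separate the two, and an unsubstituted phenyl or a 4-chlorophenyl on the same nitrogen would be needed to do so. On these data alone, compound 1 gives > 50000 nM, a limit, and it differs from compound 3 in more than one place, so the role of chlorine number and placement stays open.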